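Chloro to Trifluoromethyl on the Benzothiazole Amide

The source may hold more compounds than are shown below. What is called first, only, known or untested is meant among the compounds shown, and "the series" means these compounds.

Measured compounds:
- compound 1, `COc1ccc(-n2nc(C(=O)NCC(=O)Nc3nc4ccccc4s3)c3ccccc3c2=O)cc1`: 25000 nM
- compound 2, `COc1ccc(-n2c(SCC(=O)Nc3nc4ccc(Cl)cc4s3)nc3c(c2=O)SCC3)cc1`: 35 nM
- compound 3, `O=C(CNC(=O)c1nn(-c2ccccc2)c(=O)c2ccccc12)Nc1nc2ccc(Cl)cc2s1`: 30 nM

In an assay on L cells for inhibition of Protein-serine O-palmitoleoyltransferase porcupine (Mus musculus), read by reporter gene assay, with a stated time of 24 h (on this read-out lower numbers stand for an effect already at smaller amounts and higher numbers for an effect only at larger amounts of compound), compound 2 gives 35 nM, the second highest of the three numbers. Compound 3 gives 30 nM, which lies within the scatter of compound 2, so the two cannot be told apart. Compound 1 gives 25000 nM, a much higher number, beyond the scatter.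

Compound 4, `COc1ccc(-n2c(SCC(=O)Nc3nc4ccc(C(F)(F)F)cc4s3)nc3c(c2=O)SCC3)cc1`, is not yet measured. It differs from compound 2 by trifluoromethyl in place of chloro on an aromatic carbon. Within the data shown here, no measured pair shows this change, so the size of its step is unknown. Because compound 2 gives 35 nM and the change is small, compound 4 is expected to stay close, with an estimated step of a 1.4-fold higher number from compound 2 to compound 4 (0.15 log units; within the scatter) in this assay, near or within the scatter. Compound 4 is thus estimated at 50 nM, ranging from 15 nM to 160 nM.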

Compound 4, half-maximal effective concentration: 100 nM
Compound 4: the middle estimate sits 2.0-fold (0.30 log units) below what was measured, and the stated range covers the measured number.
By their numbers in this assay, from the lowest: compounds 3 and 2 (each within the scatter of the next); then compound 4; then compound 1.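

In this assay, trifluoromethyl in place of chloro on this aromatic carbon gives a 2.9-fold higher number from compound 2 to compound 4 (0.46 log units; beyond the scatter), so the number does respond to the group here, though only modestly. The hydrogen-bond donor and acceptor counts stay the same across this change, while the entering group carries more heavy atoms. Nothing available explains the step.

From the compounds shown here alone, it remains open whether fluoro, methyl, methoxy or an amine on this carbon would stay near compound 2. Going by these compounds, it also remains open whether the same change on compound 3 would give a similar step.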